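Notes on the series: trifluoromethoxy on compound 3

This account rests on a few compounds, and the source may have more. Where it says the series, first, only, none or still open, it means among the compounds named here.

Measured so far in an ADME assay on MRC5 cells (Homo sapiens) for cytotoxicity, read by fluorescence and resazurin assay, with a stated time of 3 days (a lower number here means a stronger inhibitor, a higher number a weaker inhibitor), for this series:
- compound 1 `Cc1ccc(Oc2cccc(CN3CCC(n4cc(C)c(=O)[nH]c4=O)CC3)c2)cc1` reads > 64000 nM as a limit
- compound 2 `Cc1cn(C2CCN(Cc3cccc(Oc4cccnc4)c3)CC2)c(=O)[nH]c1=O` reads > 64000 nM as a limit
- compound 3 `Cc1cn(C2CCN(Cc3cccc(Oc4ccccc4)c3)CC2)c(=O)[nH]c1=O` reads "not determined" (no result reported) with no result reported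

Compound 3 has no number of its own in this assay and so cannot be placed on the scale. Within the data shown here, the only values nearby are limits and not numbers: compound 1 and compound 2 stand at the limit of > 64000 nM in this assay, at which 2 of the 3 values shown sit, in these notes.

Compound 4 `Cc1cn(C2CCN(Cc3cccc(Oc4cccc(OC(F)(F)F)c4)c3)CC2)c(=O)[nH]c1=O` carries trifluoromethoxy in place of hydrogen on an aromatic carbon of compound 3, and the change counts as trifluoromethoxy in place of hydrogen on an aromatic carbon in full.

Among the measured compounds shown here, the only measured step is a step that the two limits leave unreadable from compound 1 to compound 2 and it gives no size to carry over to this change. With no readable step and no starting number, the expectation in this assay is no step beyond the scatter. Any shift that does appear is expected to run toward a lower number, and another report of only a limit is the likeliest outcome. For compound 4 the estimated value is 50000 nM in this assay, with an expected range from 20000 nM to 64000 nM on that scale.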

Compound 4, half-maximal inhibitory concentration: 5260 nM
Estimate against measurement, compound 4: 9.5-fold (0.98 log units) above; the measured number lies below the stated range.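

In this assay compound 4 is the only compound shown that reads as a number and not as a limit, so the aryl group on the oxygen can bring this read-out into the measurable range. Putting 3-(trifluoromethoxy)phenyl on the oxygen in place of pyridin-3-yl gives an at least 12-fold lower number from compound 2 to compound 4 (1.08 log units; beyond the scatter) and in place of 4-methylphenyl gives an at least 12-fold lower number from compound 1 to compound 4 (1.08 log units; beyond the scatter) with both sizes resting on a limit at the starting compound. The step between compound 1 and compound 2 cannot be read and compound 3 has no result, so the size of the change from phenyl to 3-(trifluoromethoxy)phenyl stays unknown, and the other readable values remain limits: the limit of > 64000 nM in this assay, at which 2 of the 4 values shown sit.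

The compounds shown do not tell whether the gain belongs to trifluoromethoxy itself or to any sizeable group at this carbon, meta to a large group. A methoxy group, a trifluoromethyl group or a carboxylic acid at the same place would test this, and a trifluoromethoxy group on the pyridin-3-yl ring of compound 2 would show whether the carbon-only ring is needed for the lower number.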